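Moving the chlorine on a phenylurea: compound 1 to compound 3

The compounds below may be only part of what the source reports. "The series", "measured", "known", "first", "only" and "open" are said of these compounds alone.

Going by the values given here, compound 1 `CC1(C)CC(NC(=O)Nc2cccc(Cl)c2)c2cc(Cl)ccc2O1` is the only compound here with a number: in a functional assay on B16-F10 cells (Mus musculus) for inhibition, read by MTT assay, with a stated time of 72 h (a lower number here means a stronger inhibitor, a higher number a weaker inhibitor), compound 1 gives 25000 nM, a weak result. Compound 2 `CC1(C)CC(NC(=O)Nc2cccc(Cl)c2)c2cc(F)ccc2O1` carries a fluorine on the shared core instead, but in this assay compound 2 shows "not determined" (no result reported). Compound 3 `CC1(C)CC(NC(=O)Nc2ccccc2Cl)c2cc(Cl)ccc2O1` differs from compound 1 only in the chlorophenyl group: 2-chlorophenyl in place of 3-chlorophenyl on an amide-type nitrogen. Among the compounds with values here, no measured pair shows what such a shift does, so the step from compound 1 to compound 3 is expected to be small, within the scatter, at most a slight loss: a 1.2-fold higher number from compound 1 to compound 3 (0.08 log units; within the scatter). Compound 3 is therefore estimated at 30000 nM, likely between 10000 nM and 80000 nM.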

Compound 3, half-maximal inhibitory concentration: 20000 nM
For compound 3 the middle estimate is 1.5-fold (0.18 log units) above the measured one, within the range that was stated.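

Moving the chlorine gives the first measured step on this phenyl group, attached to an amide-type nitrogen (a 1.3-fold lower number from compound 1 to compound 3 (0.10 log units; within the scatter)). This assay therefore does not separate 2-chlorophenyl from 3-chlorophenyl here, and the two compounds sit at a similar weak level. Nothing measured here offers an explanation for this result.

From the compounds shown here alone, what an amine, a carboxylic acid or a methoxy group would do in place of the chlorine stays open. Compound 2 has no number, so steps involving the fluorine on the shared core cannot be read.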